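Trifluoromethoxy for Trifluoromethyl on a Second Core

The source may report more compounds than this note shows. Statements on the series, on what has been measured and on what is new or still open speak of the compounds shown alone.

Compound 1 `CC(O)(CSc1ccc(C(F)(F)F)cc1)C(=O)Nc1ccc(S(F)(F)(F)(F)F)cc1` and compound 2 `CC(O)(CSc1ccc(OC(F)(F)F)cc1)C(=O)Nc1ccc(S(F)(F)(F)(F)F)cc1` share one core and differ in a single group. In a functional assay on VCaP cells (Homo sapiens) for antiproliferative activity, read by propidium iodide staining, with a stated time of 96 h (on this read-out lower numbers stand for stronger inhibition and higher numbers for weaker inhibition), compound 1 gives 24800 nM, and compound 2 gives 16000 nM. The change between them is trifluoromethoxy in place of trifluoromethyl on an aromatic carbon, and it brought a 1.6-fold lower number from compound 1 to compound 2 (0.19 log units; within the scatter).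

Compound 3 `CC(O)(CSc1ccc(C(F)(F)F)cc1)C(=O)Nc1cccc(S(F)(F)(F)(F)F)c1` is built from the same atoms as compound 1, joined differently; the difference between the two cores is not broken down here. In this assay compound 3 gives 27300 nM, a number that sits close to those of compound 1 and compound 2.

Compound 4 `CC(O)(CSc1ccc(OC(F)(F)F)cc1)C(=O)Nc1cccc(S(F)(F)(F)(F)F)c1` has not yet been measured. It stands to compound 3 as compound 2 stands to compound 1: the change is trifluoromethoxy in place of trifluoromethyl on an aromatic carbon, the same change at the same place, made twice among these four compounds. Going by the values given here, a step of similar size is expected here, a 1.5-fold lower number from compound 3 to compound 4 (0.18 log units; within the scatter), because a 1.6-fold lower number from compound 1 to compound 2 (0.19 log units; within the scatter) is the only earlier example of this change. With a single example to lean on, the expectation is loose. For compound 4 in this assay the estimate is 18000 nM, between 9000 nM and 36000 nM.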

Compound 4, half-maximal inhibitory concentration: 28500 nM
The estimate for compound 4 lay 1.6-fold (0.20 log units) below the measured number; low and high end bracket the measured number.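

In this assay, placing trifluoromethoxy where trifluoromethyl stood on the second core gave a 1.0-fold higher number from compound 3 to compound 4 (0.02 log units; within the scatter), so on this core, as on the first, the step stays within the usual spread of repeated measurements. Set side by side, the two steps give no sign that this change behaves differently on the two cores: the same change on two cores in this assay, a 1.6-fold lower number (0.19 log units; within the scatter) from compound 1 to compound 2 and a 1.0-fold higher number (0.02 log units; within the scatter) from compound 3 to compound 4, 1.6-fold (0.21 log units) apart, within the scatter of two such steps. Going by these compounds alone, this agreement does not prove that the change carries over reliably, as each core offers only one pair, and with both steps this small, a real difference between the cores could stay hidden in the scatter.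

The compounds shown carry only trifluoromethyl or trifluoromethoxy on this aromatic carbon, so it remains open how a nitrile, a chlorine or an amine there would read in this assay, and whether any such group would separate the two cores more clearly. The sulfur link is also the same in all four compounds, which leaves open what a sulfonyl group in its place would do.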